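This account rests on a few compounds, and the source may have more. Where it says the series, first, only, none or still open, it means among the compounds named here.

Working notes on the series. Among the measured compounds shown here, compound 3 `O=C(Nc1cccc(-c2oc3cc(-c4ccc(F)cc4)ccc3c(=O)c2O)c1)c1ccc([N+](=O)[O-])cc1` gives 2440 nM in a functional assay on A549 cells (Homo sapiens) for antiproliferative activity, read by CCK-8 assay, with a stated time of 72 h (a lower number here means a stronger inhibitor, a higher number a weaker inhibitor), the lowest of the three numbers so far. Compound 1 `O=C(Nc1cccc(-c2oc3cc(-c4ccc(F)cc4)ccc3c(=O)c2O)c1)c1ccc(Cl)cc1` gives 10800 nM in this assay, and compound 2 `O=C(Nc1cccc(-c2oc3cc(-c4ccc(F)cc4)ccc3c(=O)c2O)c1)c1ccc(Br)cc1` gives 13500 nM; the step of a 1.3-fold higher number from compound 1 to compound 2 (0.10 log units; within the scatter) is within the scatter, whereas a 4.4-fold lower number from compound 1 to compound 3 (0.65 log units; beyond the scatter) and a 5.5-fold lower number from compound 2 to compound 3 (0.74 log units; beyond the scatter) both lie beyond it.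

Compound 4 `CCCc1ccc(C(=O)Nc2cccc(-c3oc4cc(-c5ccc(F)cc5)ccc4c(=O)c3O)c2)cc1` differs from compound 3 only at the para position of the benzamide ring: propyl in place of nitro on an aromatic carbon. The two steps that bear on this are the ones into compound 3, a 4.4-fold lower number from compound 1 to compound 3 (0.65 log units; beyond the scatter) and a 5.5-fold lower number from compound 2 to compound 3 (0.74 log units; beyond the scatter), where nitro in place of chloro or bromo lowered the number modestly. Removing the nitro again, now for propyl, is expected to run the other way, with a rise of roughly that size, since no measured replacement other than nitro gave a low number. The estimated step is therefore a 3.7-fold higher number from compound 3 to compound 4 (0.57 log units; beyond the scatter). For compound 4 the expected value in this assay is 9000 nM, with a range from 3000 nM to 27000 nM.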

Compound 4, half-maximal inhibitory concentration: 47600 nM
For compound 4 the middle estimate is 5.3-fold (0.72 log units) below the measured one; measured number above the stated range.
By their numbers in this assay, from the lowest: compound 3; then compounds 1 and 2 (each within the scatter of the next); then compound 4.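

In this assay, among the compounds shown here, this aromatic carbon, para to a large group, carries a wider range than the chloro, bromo and nitro compounds showed: a 20-fold higher number from compound 3 to compound 4 (1.29 log units; beyond the scatter) is the largest step so far. Propyl also separates from both halogens, with a 3.5-fold higher number from compound 2 to compound 4 (0.55 log units; beyond the scatter) and a 4.4-fold higher number from compound 1 to compound 4 (0.64 log units; beyond the scatter), which places chloro and bromo between nitro and propyl and leaves compound 4 with the highest number of the four. No measurement at hand accounts for this order.

From the compounds shown here alone, whether the high number belongs to propyl alone or extends to a methyl or a longer chain remains open. Going by these compounds, it is also open where an amine or a carboxylic acid at this carbon would fall relative to nitro.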